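Anilino-dione series: ethoxy replaced by trifluoromethyl

The compounds below may be only part of what the source reports. "The series", "measured", "known", "first", "only" and "open" are said of these compounds alone.

Working notes on four compounds that share one core. Going by the values given here, compound 1 `CCOc1ccc(NC2=CC(=O)c3c(nc4n3[C@H]3OC[C@@H](O)[C@H]3OC4)C2=O)cc1` is the only member with a numerical result; in a functional assay on HeLa cells (Homo sapiens) for inhibition, read by sulforhodamine B assay (a lower number here means a stronger inhibitor, a higher number a weaker inhibitor), compound 1 gives 14400 nM. Compound 2 `O=C1C=C(Nc2ccc(C(F)(F)F)cc2)C(=O)c2c1nc1n2[C@H]2OC[C@@H](O)[C@H]2OC1` carries a 4-(trifluoromethyl)phenyl amine. In this assay compound 2 gives only a limit, > 8000 nM. Compound 3 `O=C1C=C(N2CCCCC2)C(=O)c2c1nc1n2[C@H]2OC[C@@H](O)[C@H]2OC1` has no arylamine at all. In this assay compound 3 likewise gives only a limit, > 16000 nM. So compound 1 stands as the sole quantified point, with the two other values of the set sitting at assay limits rather than at numbers.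

The step under consideration is from compound 1 to compound 4 `O=C1C(Nc2ccc(C(F)(F)F)cc2)=CC(=O)c2c1nc1n2[C@H]2OC[C@@H](O)[C@H]2OC1`: trifluoromethyl in place of ethoxy on an aromatic carbon. Among the compounds with values here, no measured pair in this set isolates this change, so the size of the step rests on expectation. Compound 4 places the same 4-(trifluoromethyl)phenyl group that compound 2 bears on its core, and compound 2 reaches only a limit in this assay, so the expectation is that the step weakens rather than strengthens, with a fair chance that compound 4 too returns a limit. The expected step is a 1.3-fold higher number from compound 1 to compound 4 (0.10 log units; within the scatter). For compound 4 in this assay the estimate is 18000 nM, within 6000 nM to 50000 nM.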

Compound 4, half-maximal inhibitory concentration: 8920 nM
Beside the measured number, compound 4's estimate is 2.0-fold (0.30 log units) above it; low and high end bracket the measured number.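

In this assay, the change from 4-ethoxyphenyl to 4-(trifluoromethyl)phenyl on the shared core gives a 1.6-fold lower number from compound 1 to compound 4 (0.21 log units; within the scatter), so compound 1 and compound 4 cannot be told apart at this position, and trifluoromethyl reads the same as ethoxy on this aromatic carbon. Going by these compounds alone, this is the first pair with a number at both ends, and it shows that the 4-(trifluoromethyl)phenyl group can return a number rather than a limit. Compound 2, which bears the same 4-(trifluoromethyl)phenyl group, remains a limit and not a number: the limit of > 8000 nM in this assay, at which 1 of the 4 values shown sits.

The reading of this position rests on a single pair, and a carboxylic acid, a dimethylamino group or a longer alkoxy chain such as butoxy on the same aromatic carbon would test whether the flat result extends beyond ethoxy and trifluoromethyl. Also open is how an arylamine compares with the piperidine of compound 3, whose value is only a limit: the limit of > 16000 nM in this assay, at which 1 of the 4 values shown sits.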